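Bromo for Iodo in a Rat Clearance Pair

This account rests on a few compounds, and the source may have more. Where it says the series, first, only, none or still open, it means among the compounds named here.

In an in vivo ADME assay on the whole organism for pharmacokinetics, with Rattus norvegicus as the target, at a dose of 1 mg/kg by the intravenous route (a higher number here means faster removal of the compound, a lower number slower removal), compound 1 (`O=C(NOC[C@H](O)CO)c1ccc2cnsc2c1Nc1ccc(I)cc1F`) gives 15 mL/min/kg as its value. Compound 2 (`O=C(NOCCO)c1ccc2[nH]ncc2c1Nc1ccc(I)cc1F`) gives 36 mL/min/kg and so holds the higher of the two numbers, a gap beyond the usual scatter. Compound 3 (`O=C(NOCCO)c1ccc2[nH]ncc2c1Nc1ccc(Br)cc1F`), not yet measured, carries bromo in place of iodo on an aromatic carbon and is otherwise the same as compound 2. Going by the values given here, no measured pair shows this change, so the size of the step is a judgement. A step of a 1.1-fold lower number from compound 2 to compound 3 (0.05 log units; within the scatter) is expected to stay within the scatter, with no firm direction. Compound 3 is estimated at 32 mL/min/kg (range 16 mL/min/kg to 60 mL/min/kg) in this measurement.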

Compound 3, clearance: 54 mL/min/kg
For compound 3 the middle estimate is 1.7-fold (0.23 log units) below the measured one; low and high end bracket the measured number.
By their numbers in this assay, from the lowest: compound 1; then compounds 2 and 3 (each within the scatter of the next).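

In this assay, bromo in place of iodo on the aromatic carbon para to a large group gives a 1.5-fold higher number from compound 2 to compound 3 (0.18 log units; within the scatter). Going by these compounds alone, this is the first comparison here that isolates a single place, and at this position on the core of compound 2 the exchange of one halogen for the other does not separate the two compounds. No measured evidence shown here bears on this result. From the compounds shown here alone, whether chloro, a nitrile or a methyl group at this position would give a step beyond the scatter remains open. So does whether the same exchange would behave alike on the core of compound 1.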